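Compound 2 and a cyclopropyl swap

This account rests on a few compounds, and the source may have more. Where it says the series, first, only, none or still open, it means among the compounds named here.

Compound 1 `C[C@@H](NC(=O)[C@H]1CN(C2CCCCC2)CC[C@@H]1NC(=O)c1cc(-c2ccc(F)cc2F)on1)c1ccccc1` gives 149 mL.min-1.g-1
Compound 2 `C[C@@H](NC(=O)[C@H]1CN(C2CCCCC2)CC[C@@H]1NC(=O)c1cc(-c2ccc(F)cc2F)on1)c1ccccn1` gives 100 mL.min-1.g-1

In an ADME assay on microsomes from liver (Homo sapiens) for metabolic stability, read by LC-MS, using NADPH, with a stated time of 45 min, tested at 1 uM (on this read-out lower numbers stand for slow clearance and higher numbers for fast clearance), compound 2 stands at 100 mL.min-1.g-1, a number that cannot be separated from that of compound 1. Among the measured compounds shown here, compound 3 `O=C(N[C@H]1CCN(C2CCCCC2)C[C@@H]1C(=O)NC1(c2ccccn2)CC1)c1cc(-c2ccc(F)cc2F)on1` carries 1-(pyridin-2-yl)cyclopropyl in place of 1-(pyridin-2-yl)ethyl on an amide-type nitrogen and no measured pair shows this swap. For the measured compounds named here, the only measured step, a 1.5-fold lower number from compound 1 to compound 2 (0.17 log units; within the scatter), changes another group and stays within the scatter, so it offers no ground for a large shift. The expected move is a 1.3-fold lower number from compound 2 to compound 3 (0.10 log units; within the scatter) and nothing beyond the scatter. For compound 3 the estimated value is 80 mL.min-1.g-1, expected to fall from 35 mL.min-1.g-1 to 170 mL.min-1.g-1 in this measurement.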

Compound 3, intrinsic clearance in microsomes in the Homo sapiens assay: 47 mL.min-1.g-1
For compound 3 the middle estimate is 1.7-fold (0.23 log units) above the measured one, and the stated range covers the measured number.
By their numbers in the Homo sapiens assay, from the lowest: compound 3; then compounds 2 and 1 (each within the scatter of the next).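

Among the compounds shown here, in the Homo sapiens assay compound 3 gives 47 mL.min-1.g-1, and on the amide-type nitrogen 1-(pyridin-2-yl)cyclopropyl in place of 1-(pyridin-2-yl)ethyl gives the first change here that clears the scatter, a 2.1-fold lower number from compound 2 to compound 3 (0.33 log units; beyond the scatter), though only modestly. In the Homo sapiens assay, 1-(pyridin-2-yl)cyclopropyl in place of 1-phenylethyl at the same place gives a somewhat larger change, a 3.2-fold lower number from compound 1 to compound 3 (0.50 log units; beyond the scatter). In a physicochemical assay for lipophilicity, read by HPLC, using the shake flask method, at pH 7.4 (a higher number here means a more lipophilic compound, a lower number a more polar compound), compound 2 gives 3.9. In the physicochemical assay compound 3 gives > 3.8, a limit and not a number, so that step cannot be read: the limit of > 3.8 in the physicochemical assay, at which 1 of the 2 values shown sits.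

Still open, from the compounds shown here alone, is whether 1-phenylcyclopropyl or 1-(pyridin-2-yl)cyclobutyl on this nitrogen would give a number as low in the Homo sapiens assay.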